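The source may report more compounds than this note shows. Statements on the series, on what has been measured and on what is new or still open speak of the compounds shown alone.

Measured so far:
Compound 1 `Oc1ccccc1-c1cc(-c2ccccc2OC(F)(F)F)cc(-c2ccccc2O)n1` — in a functional assay on HeLa cells (Homo sapiens) for inhibition (on this read-out lower numbers stand for stronger inhibition and higher numbers for weaker inhibition), compound 1 gives 9750 nM.
Compound 2 `Oc1cccc(-c2cc(-c3ccccc3OC(F)(F)F)cc(-c3ccccc3O)n2)c1` — in this assay compound 2 gives 15200 nM.

Among the measured compounds shown here, compound 2 sits at one end of these two numbers, and the only step that reaches it, a 1.6-fold higher number from compound 1 to compound 2 (0.19 log units; within the scatter), lies within the usual scatter, so the two compounds cannot be told apart with confidence. Compound 3 `Oc1ccc(-c2cc(-c3ccccc3OC(F)(F)F)cc(-c3ccccc3O)n2)cc1` has not yet been measured. It differs from compound 2 in one place: 4-hydroxyphenyl in place of 3-hydroxyphenyl on an aromatic carbon. For the measured compounds named here, the one measured step that bears on this kind of change is the move of the hydroxyl group in a 1.6-fold higher number from compound 1 to compound 2 (0.19 log units; within the scatter), which stayed within the scatter. On that basis the further move of the hydroxyl group is expected to bring no step beyond the scatter either, and the estimated shift is a 1.2-fold higher number from compound 2 to compound 3 (0.07 log units; within the scatter). Compound 3 is therefore expected to give about 18000 nM, with a plausible range from 6000 nM to 55000 nM.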

Compound 3, half-maximal inhibitory concentration: 6010 nM
For compound 3 the middle estimate is 3.0-fold (0.48 log units) above the measured one; the range from low to high includes it.
By their numbers in this assay, from the lowest: compounds 3, 1 and 2 (each within the scatter of the next, the first and the last beyond it).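

In this assay, the position next to the ring nitrogen now shows its first step beyond the scatter: placing 4-hydroxyphenyl there in place of 3-hydroxyphenyl gives a 2.5-fold lower number from compound 2 to compound 3 (0.40 log units; beyond the scatter), although this step is only modest. The other comparison, a 1.6-fold lower number from compound 1 to compound 3 (0.21 log units; within the scatter), does not separate the 2-hydroxyphenyl and 4-hydroxyphenyl groups, so the location of the hydroxyl matters clearly only between the 3-hydroxyphenyl and 4-hydroxyphenyl groups. Nothing available explains this difference.

The compounds shown leave open whether the hydroxyl itself is needed on this ring, which a methoxy group or an amine in its place would help to test. They also leave open whether the step from 3-hydroxyphenyl to 4-hydroxyphenyl would persist if a methoxy group replaced the hydroxyl on the other 2-hydroxyphenyl group.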